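Swapping the Sulfonyl Cap for a Carbamate

This account rests on a few compounds, and the source may have more. Where it says the series, first, only, none or still open, it means among the compounds named here.

In a functional assay on the whole organism (artery) for inhibition, with Rattus norvegicus as the target, at a dose of 3 mg/kg by the intraduodenal route (on this read-out lower numbers stand for less inhibition and higher numbers for more inhibition at the one dose given (going by the name of the read-out)), compound 1 `CCCCc1ccc(CN(C(C)C)S(C)(=O)=O)c(=O)n1Cc1ccc(-c2ccccc2-c2nn[nH]n2)cc1` gives 82.7%, while compound 2 `CCCCc1ccc(CNS(=O)(=O)c2ccccc2)c(=O)n1Cc1ccc(-c2ccccc2-c2nn[nH]n2)cc1` gives 25.2%, the lowest of the two numbers measured; the step is a number 57.5 percentage points lower from compound 1 to compound 2 (beyond the scatter). Compound 3 `CCCCc1ccc(CNC(=O)OC(C)(C)C)c(=O)n1Cc1ccc(-c2ccccc2-c2nn[nH]n2)cc1` differs from compound 2 in one place: tert-butoxycarbonyl in place of phenylsulfonyl on an amine nitrogen. Within the data shown here, only the step from compound 1 to compound 2 touches the same amine nitrogen, and it was large, yet neither measured compound carries a tert-butoxycarbonyl group, so the direction remains open. Compound 3 is expected to show a step of a number 16.8 percentage points higher from compound 2 to compound 3 (beyond the scatter), giving an estimated 42% in this assay, within a range of 15% to 72%.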

Compound 3, a percentage reported as inhibition, in the whole organism at one dose (the size of the read-out at that dose, not a potency): 68.9%
For compound 3 the middle estimate is 26.9 percentage points below the measured one; the range from low to high includes it.
By their numbers in this assay, from the lowest: compound 2; then compound 3; then compound 1.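

On this amine nitrogen the capping group decides much of the read-out: tert-butoxycarbonyl in place of phenylsulfonyl gives a number 43.7 percentage points higher from compound 2 to compound 3 (beyond the scatter) and so recovers most of what compound 2 had lost. The isopropyl(methylsulfonyl)amino group is not needed for a high number, although replacing it still leaves a number 13.8 percentage points lower from compound 1 to compound 3 (beyond the scatter). No available evidence bears on why these caps differ. From the compounds shown here alone, whether an acetyl or benzoyl group on this nitrogen would read closer to compound 3 or to compound 2 remains open. So does the outcome of placing an isopropyl group on the nitrogen of compound 3.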